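Dimethylamino in place of phenoxy on the aryl-pyridine arm

The source may hold more compounds than are shown below. What is called first, only, known or untested is meant among the compounds shown, and "the series" means these compounds.

Compound 1 `COc1cc(C)cc(-c2nn(CC#N)cc2-c2ccc(-c3cccc(C(C)=O)c3)nc2)c1` reaches only a limit in a functional assay on LOX IMVI cells (Homo sapiens) for inhibition, read by sulforhodamine B assay, with a stated time of 48 h; on this read-out lower numbers stand for stronger inhibition of growth and higher numbers for weaker inhibition of growth: compound 1 gives > 100000 nM, which is a limit rather than a number, as the limit of > 100000 nM in this assay, at which 1 of the 2 values shown sits, records. Among the compounds with values here, compound 2 `Cc1cc(O)cc(-c2nn(CC#N)cc2-c2ccnc(-c3ccc(Oc4ccccc4)cc3)c2)c1` supplies the sole number in this assay, at 3390 nM. Compound 3 `Cc1cc(O)cc(-c2nn(CC#N)cc2-c2ccnc(-c3ccc(N(C)C)cc3)c2)c1` carries dimethylamino in place of phenoxy on an aromatic carbon. Within the data shown here, no measured step with a comparable change exists, so the expectation for compound 3 rests on compound 2 alone, and the step from compound 2 to compound 3 is estimated at a 1.8-fold higher number from compound 2 to compound 3 (0.25 log units; within the scatter), a modest weakening that may not exceed the scatter. Compound 3 is therefore expected to give 6000 nM, within 1500 nM to 25000 nM.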

Compound 3, concentration for total growth inhibition: 17800 nM
The estimate for compound 3 lay 3.0-fold (0.47 log units) below the measured number; the measured number falls inside the stated range.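

In this assay, within the data shown here, dimethylamino in place of phenoxy on this aromatic carbon gives a 5.3-fold higher number from compound 2 to compound 3 (0.72 log units; beyond the scatter) as the only readable step. Growth inhibition at this position therefore depends on the group it carries, and between these two groups phenoxy gives the lower number. Nothing shown accounts for the step.

Among these compounds, with only two groups, the loss of the carbon ring cannot be separated from the change from ether oxygen to amine nitrogen. Anilino or morpholine on the same carbon remains an open comparison.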